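Removing the Carbamoylmethyl Arm from Compound 1

This account rests on a few compounds, and the source may have more. Where it says the series, first, only, none or still open, it means among the compounds named here.

For the measured compounds named here, compound 1 `NC(=O)C[C@H](NC(=O)c1ccc(C#Cc2ccccc2)cc1)C(=O)NO` is the only member of this set with a numerical reading: in a physicochemical assay for lipophilicity (on this read-out lower numbers stand for lower lipophilicity and higher numbers for higher lipophilicity), compound 1 gives 1. Compound 2 `O=C(NC1(C(=O)NO)CCOCC1)c1ccc(C#Cc2ccccc2)cc1` reaches only a limit of the assay, as compound 2 gives > 4 in this assay, which is the limit of > 4 in this assay, at which 1 of the 3 values shown sits. Compound 3 `O=C(NC1(C(=O)NO)CCN(Cc2ccccc2)CC1)c1ccc(C#Cc2ccccc2)cc1` likewise stops at a limit, since compound 3 gives > 3, which is the limit of > 3 in this assay, at which 1 of the 3 values shown sits. No two of these compounds differ in a single place, so no measured step is available. Compound 4 `O=C(CNC(=O)c1ccc(C#Cc2ccccc2)cc1)NO` has not yet been measured; it differs from compound 1 in one place: hydrogen in place of carbamoylmethyl on a saturated chain carbon bound to an amide-type nitrogen and a carbonyl carbon. Without a measured step to lean on, the change can only be anticipated, and the expected step of a number 0.70 log units higher from compound 1 to compound 4 (beyond the scatter) is a rise beyond the usual scatter. Compound 4 is therefore estimated at 1.7, between 1.2 and 2.3.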

Compound 4, distribution coefficient: 3
For compound 4 the middle estimate is 1.30 log units below the measured one; the whole stated range lies below it.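

For the compounds shown here, on this assay, hydrogen in place of carbamoylmethyl on a saturated chain carbon bound to an amide-type nitrogen and a carbonyl carbon gives a number 2.00 log units higher from compound 1 to compound 4 (beyond the scatter), the first measured single-place step in this set. Going by these compounds alone, it shows that this position strongly affects the read-out, which the earlier compounds could not show without such a step. Nothing measured here accounts for the size of this step.

A single step leaves open how a methyl group, a carboxylic acid arm or an amine on the same carbon would read. It also leaves open whether this change would give a similar step on another core.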